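Adding 3-(1H-1,2,4-triazol-1-yl)propyl to the Core of Compound 1

A few compounds are considered here, and "the series" means these few. Any claim that something is new, unique, unknown or untested is made for them only; others in the source may bear on it.

Compound 1 `Cn1cc(C2=C(c3n[nH]c4ncccc34)C(=O)NC2=O)c2ccccc21`: 62000 nM
Compound 2 `Cn1cc(C2=C(c3n[nH]c4ncccc34)C(=O)N(c3cccc4ccccc34)C2=O)c2ccccc21`: > 100000 nM
Compound 3 `Cn1cc(C2=C(c3nn(CCCN4CCCCC4)c4ncccc34)C(=O)N(c3ccc(Cl)cc3)C2=O)c2ccccc21`: > 100000 nM

Among the measured compounds shown here, in a functional assay on KB cells (Homo sapiens) for antiproliferative activity, read by MTT assay, with a stated time of 48 h (on this read-out lower numbers stand for stronger inhibition and higher numbers for weaker inhibition), compound 1 gives 62000 nM, the only number among the three compounds. Compound 2 reports only a limit, > 100000 nM. Compound 3 likewise reports only a limit, > 100000 nM. Compound 4 `Cn1cc(C2=C(c3nn(CCCn4cncn4)c4ncccc34)C(=O)NC2=O)c2ccccc21` differs from compound 1 by 3-(1H-1,2,4-triazol-1-yl)propyl in place of hydrogen on an aromatic nitrogen. For the measured compounds named here, the one measured step, an at least 1.6-fold higher number from compound 1 to compound 2 (0.20 log units; that floor lies within the scatter), concerns the amide-type nitrogen rather than the aromatic nitrogen, and its floor lies within the scatter, so it gives little guidance. Compound 3, which carries a different propyl chain on the aromatic nitrogen together with a second change, sits at the limit of > 100000 nM in this assay, at which 2 of the 3 values shown sit. Compound 4 is therefore expected to show no gain and possibly a loss, a 1.3-fold higher number from compound 1 to compound 4 (0.11 log units; within the scatter). The estimate for compound 4 is 80000 nM, ranging from 30000 nM to 200000 nM.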

Compound 4, half-maximal inhibitory concentration: > 100000 nM
Compound 4 was reported as a limit; the forecaster's own chance of this, stated with the estimate: 40%; at least 1.2-fold (0.09 log units) between middle value and limit.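

On the aromatic nitrogen, 3-(1H-1,2,4-triazol-1-yl)propyl shows no gain over the hydrogen of compound 1 in this assay, the step being an at least 1.6-fold higher number from compound 1 to compound 4 (0.20 log units; that floor lies within the scatter). Unlike compound 3, which carries a second change, compound 4 keeps the amide hydrogen, so this change is read alone. Compound 4 is reported only as a limit, so the full size of the step stays unknown: the limit of > 100000 nM in this assay, at which 3 of the 4 values shown sit.

Going by these compounds, whether a morpholine or a carboxylic acid at the end of the propyl chain, with the amide hydrogen kept, would give a measurable number remains open.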